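This account rests on a few compounds, and the source may have more. Where it says the series, first, only, none or still open, it means among the compounds named here.

Values so far in an ADME assay on S9 fraction from liver (Rattus norvegicus) for metabolic stability, read by LC-MS, using NADPH, with a stated time of 30 min (a higher number here means that more of the compound is left, a lower number that less of the compound is left), are these:

- compound 1 `CCCCCCCCc1ccc(OCC(=O)Cn2nnc(-c3ccc(C(=O)OC)cc3)n2)cc1` gives 64%
- compound 2 `CCCCCCCCc1ccc(OCC(=O)Cn2nnc(-c3ccc(S(=O)(=O)N(C)C)cc3)n2)cc1` gives 65%
- compound 3 `CCCCCCCCc1ccc(OCC(=O)Cn2nnc(-c3cccs3)n2)cc1` gives 8%

Compound 3 stands lowest of the three, and both other compounds lie beyond the scatter from it. The next compound, compound 4 `CCCCCCCCc1ccc(OCC(=O)Cn2nnc(-c3ccc(C(=O)O)cc3)n2)cc1`, differs from compound 3 in one place: 4-carboxyphenyl in place of thiophen-2-yl on an aromatic carbon so that 4-carboxyphenyl replaces thiophen-2-yl on an aromatic carbon of the five-membered aromatic ring with 4 nitrogen.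

Among the compounds with values here, two measured steps bear most directly on this change, and both are large and run the opposite way. Replacing 4-(methoxycarbonyl)phenyl with thiophen-2-yl gave a number 56 percentage points lower from compound 1 to compound 3 (beyond the scatter) and replacing 4-(dimethylsulfamoyl)phenyl with thiophen-2-yl gave a number 57 percentage points lower from compound 2 to compound 3 (beyond the scatter) in the same test. Exchanging one group on the phenyl ring for another gave a number 1 percentage points higher from compound 1 to compound 2 (within the scatter) and so made no clear difference.

Compound 4 carries a phenyl ring, as compound 1 and compound 2 do, so a large upward move is expected. Within the data shown here, no compound with a 4-carboxyphenyl group has been measured yet, which leaves the size uncertain. The expected change is a number 52 percentage points higher from compound 3 to compound 4 (beyond the scatter) in this assay on this reasoning. For compound 4 the estimate is 60% with an expected range from 35% to 85% in this test.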

Compound 4, percent of the compound remaining: < 5%
Compound 4 was reported as a limit; the forecaster's own chance of this, stated with the estimate: 2%; middle value at least 55 percentage points from the limit.
By their numbers in this assay, from the lowest: compound 3; then compounds 1 and 2 (each within the scatter of the next). At a limit, below all of these: compound 4.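

Compound 4 is reported only as a limit: the limit of < 5% in this assay, at which 1 of the 4 values shown sits.

The earlier compounds shown here suggested that a substituted phenyl ring on this aromatic carbon goes with much of the compound being left, but the group carried by that ring turns out to matter a great deal in this assay, with a number at least 60 percentage points lower from compound 2 to compound 4 (beyond the scatter) and a number at least 59 percentage points lower from compound 1 to compound 4 (beyond the scatter). The second of these steps is the smallest change in the set, hydrogen in place of methyl on an oxygen next to a carbonyl group, so a single methyl separates a well-retained compound from one at the limit. With a number at least 3 percentage points lower from compound 3 to compound 4 (that floor lies within the scatter), 4-carboxyphenyl cannot be told apart from thiophen-2-yl here, even though the two groups differ in ring and in size.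

From the compounds shown here alone, how far compound 4 really lies under the limit stays unknown, so its order relative to compound 3 is unsettled. Going by these compounds, it is also open whether a free carboxylic acid is uniquely poor on this phenyl ring, or whether a primary amide or a hydroxymethyl group in the same place would end up nearer compound 4 or nearer compound 1.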